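From Cyclohexyl to 4-Chlorophenyl

The compounds below may be only part of what the source reports. "The series", "measured", "known", "first", "only" and "open" are said of these compounds alone.

Among the measured compounds shown here, in a functional assay on MCF7 cells (Homo sapiens) for antiproliferative activity, read by MTT assay, with a stated time of 72 h (on this read-out higher numbers stand for weaker inhibition and lower numbers for stronger inhibition), compound 1 `Nc1nc(N)c2cc(CSC(=S)N3CCN(C4CCCCC4)CC3)ccc2n1` gives 6800 nM and stands highest of the three numbers so far, above compound 2 `COc1ccc(N2CCN(C(=S)SCc3ccc4nc(N)nc(N)c4c3)CC2)cc1` at 1580 nM and compound 3 `Cc1ccc(N2CCN(C(=S)SCc3ccc4nc(N)nc(N)c4c3)CC2)cc1` at 2480 nM on this read-out. For the measured compounds named here, compound 4 `Nc1nc(N)c2cc(CSC(=S)N3CCN(c4ccc(Cl)cc4)CC3)ccc2n1` has not been measured, and it carries 4-chlorophenyl in place of cyclohexyl on an amine nitrogen in a ring as its only change from compound 1. Two measured steps make a similar swap at that spot, with a 4.3-fold lower number from compound 1 to compound 2 (0.63 log units; beyond the scatter) for 4-methoxyphenyl and a 2.7-fold lower number from compound 1 to compound 3 (0.44 log units; beyond the scatter) for 4-methylphenyl. Methyl in place of methoxy gives only a 1.6-fold higher number from compound 2 to compound 3 (0.20 log units; within the scatter) between those two. A modest drop of similar size is therefore expected, and the estimated step in this assay is a 2.7-fold lower number from compound 1 to compound 4 (0.43 log units; beyond the scatter) overall. Compound 4 is expected at 2500 nM within a range of 1100 nM to 5500 nM by this estimate.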

Compound 4, half-maximal inhibitory concentration: 4880 nM
Estimate against measurement, compound 4: 2.0-fold (0.29 log units) below; measured number inside the range.
By their numbers in this assay, from the lowest: compounds 2, 3, 4 and 1 (each within the scatter of the next, the first and the last beyond it).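

In this assay 4-chlorophenyl in place of cyclohexyl gives only a 1.4-fold lower number from compound 1 to compound 4 (0.14 log units; within the scatter) and so shows that an aromatic ring at this position does not by itself bring a step beyond the scatter. Chloro in place of methoxy gives a 3.1-fold higher number from compound 2 to compound 4 (0.49 log units; beyond the scatter) while chloro in place of methyl gives a 2.0-fold higher number from compound 3 to compound 4 (0.29 log units; within the scatter) so the group carried on the aromatic ring can matter here. No evidence is at hand to explain these numbers.

Still open, from the compounds shown here alone, is how a plain phenyl, or a phenyl carrying an amine or a carboxylic acid, would read at this position.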